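Aryl amide change on a cyclopropyl sulfonamide piperidine

The source may report more compounds than this note shows. Statements on the series, on what has been measured and on what is new or still open speak of the compounds shown alone.

Measured compound:
compound 3 `O=C(c1ccc(OC(F)(F)F)cc1)N1CCC(N(C2CC2)S(=O)(=O)c2cccc(C(F)(F)F)c2)CC1` — 88%

Three compounds sharing one core were entered in an assay on cells for inhibition of Voltage-dependent L-type calcium channel subunit alpha-1C (Homo sapiens), read by FLIPR and calcium flux, tested at 3 uM; on this read-out lower numbers stand for a weaker effect and higher numbers for a stronger effect at the one concentration tested. Compound 1 `COC(=O)c1cccc(C(=O)N2CCC(N(C3CC3)S(=O)(=O)c3cccc(C(F)(F)F)c3)CC2)c1` shows "not determined" (no result reported) there, and compound 2 `CS(=O)(=O)c1ccc(C(=O)N2CCC(N(C3CC3)S(=O)(=O)c3cccc(C(F)(F)F)c3)CC2)cc1` shows "not determined" (no result reported) there, so nothing can be said of how these two behave. Going by the values given here, compound 3 `O=C(c1ccc(OC(F)(F)F)cc1)N1CCC(N(C2CC2)S(=O)(=O)c2cccc(C(F)(F)F)c2)CC1` is therefore the only compound with a number, and in this assay compound 3 gives 88%, a strong effect at the single concentration used. Among the compounds with values here, because no second measured compound exists, no step between measured compounds is known, and the size of any change cannot be read from the data.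

Compound 4 `CS(=O)(=O)c1ccccc1C(=O)N1CCC(N(C2CC2)S(=O)(=O)c2cccc(C(F)(F)F)c2)CC1` differs from compound 3 in one place: 2-(methylsulfonyl)phenyl in place of 4-(trifluoromethoxy)phenyl on a carbonyl carbon. Within the data shown here, no measured pair shows what such an exchange does on this core, so the expectation rests on compound 3 alone and carries a wide range. The step from compound 3 to compound 4 is expected to be a decrease beyond the scatter, a number 33 percentage points lower from compound 3 to compound 4 (beyond the scatter). In this assay compound 4 is estimated to give 55%, within a range from 15% to 90%.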

Compound 4, a percentage reported as inhibition, at one concentration (the size of the read-out at that concentration, not a potency): 39%
Estimate against measurement, compound 4: 16 percentage points above; the range from low to high includes it.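

In this assay the group on the carbonyl carbon now has a first measured effect: with 2-(methylsulfonyl)phenyl in place of 4-(trifluoromethoxy)phenyl, the result is a number 49 percentage points lower from compound 3 to compound 4 (beyond the scatter) on the same core. This large step shows that the read-out depends strongly on this position, which compound 3 alone could not show. Nothing available explains why the exchange has an effect of this size.

Going by these compounds alone, compounds 1 and 2 have no reported result, so no steps involving them can be read, and a single step cannot separate the effect of the methylsulfonyl group from that of the loss of trifluoromethoxy. As far as these compounds go, it also remains open how a phenyl ring carrying an amine or a carboxylic acid would behave in this assay on this core.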